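The compounds below may be only part of what the source reports. "The series", "measured", "known", "first", "only" and "open" are said of these compounds alone.

Measured so far:
compound 1, `CNCC(=O)Nc1cc(OC)ccc1C(=O)c1ccc2c(c1)C=CC(C)(C)O2`, 800 nM;
compound 2, `CCNCC(=O)Nc1cc(OC)ccc1C(=O)c1ccc2c(c1)C=CC(C)(C)O2`, 1300 nM;
compound 3, `C=C(c1ccc(OC)cc1NC(=O)CNC)c1ccc(OC)c2c1C=CC(C)(C)O2`, 320 nM.

In a functional assay on A549 cells (Homo sapiens) for antiproliferative activity, read by MTT assay, with a stated time of 48 h (on this read-out higher numbers stand for weaker inhibition and lower numbers for stronger inhibition), compound 1 and compound 2 differ by methyl in place of hydrogen on a saturated chain carbon bound to an amine nitrogen, and this change gave a 1.6-fold higher number from compound 1 to compound 2 (0.21 log units; within the scatter). Compound 3 carries a different core; how the two cores differ is not broken down here. Compound 4, `C=C(c1ccc(OC)cc1NC(=O)CNCC)c1ccc(OC)c2c1C=CC(C)(C)O2`, is not yet measured. It differs from compound 3 by methyl in place of hydrogen on a saturated chain carbon bound to an amine nitrogen, and the place is the same as in the earlier pair, so it is the same change. Because the earlier step was a 1.6-fold higher number from compound 1 to compound 2 (0.21 log units; within the scatter), a step of similar size is expected here, namely a 1.6-fold higher number from compound 3 to compound 4 (0.19 log units; within the scatter). Compound 4 is therefore estimated at 500 nM in this assay, expected to fall between 250 nM and 1000 nM.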

Compound 4, half-maximal inhibitory concentration: 1870 nM
Estimate against measurement, compound 4: 3.7-fold (0.57 log units) below; the whole stated range lies below it.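

In this assay, among the compounds shown here, methyl in place of hydrogen on a saturated chain carbon bound to an amine nitrogen gave a 5.8-fold higher number from compound 3 to compound 4 (0.77 log units; beyond the scatter), so the change did not carry over at the same size from one core to the other: the same change on two cores in this assay, a 1.6-fold higher number (0.21 log units; within the scatter) from compound 1 to compound 2 and a 5.8-fold higher number (0.77 log units; beyond the scatter) from compound 3 to compound 4, 3.6-fold (0.56 log units) apart, beyond the scatter of two such steps Only the step on the core of compound 3 lies beyond the scatter, while the step on the core of compound 1 stays within it. With one pair on each core, this shows that the step size differs between these two cores, but it does not show why, or how the change would behave on any further core.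

As far as these compounds go, whether a propylamino group or a cyclic amine such as morpholine in place of the ethylamino group would extend the larger step remains open. Also open, from the compounds shown here alone, is which part of the difference between the two cores goes with that larger step.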